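A few compounds are considered here, and "the series" means these few. Any claim that something is new, unique, unknown or untested is made for them only; others in the source may bear on it.

Values in a functional assay on NFS-60 cells (Mus musculus) for inhibition, with a stated time of 72 h (on this read-out lower numbers stand for stronger inhibition of growth and higher numbers for weaker inhibition of growth), are as follows:
- compound 1 `Nc1ncnc2c(C(=O)Nc3cccc4c3c(Br)nn4Cc3ccccn3)csc12` gives 2500 nM
- compound 2 `Nc1ncnc2c(C(=O)Nc3cccc4c3c(Br)nn4Cc3ccncc3)csc12` gives 135 nM

Among the measured compounds shown here, compound 2 stands lowest of the two numbers, with compound 1 as its only neighbour. The next compound is compound 3 `Nc1ncnc2c(C(=O)Nc3cccc4c3c(Br)nn4CC3CCCCC3)csc12`, with cyclohexyl in place of pyridin-4-yl on a saturated chain carbon bound to an aromatic nitrogen. For the measured compounds named here, one measured step bears on this, at the same place: a 19-fold lower number from compound 1 to compound 2 (1.27 log units; beyond the scatter) is large and beyond the scatter. Going by the values given here, that step swaps pyridin-2-yl for pyridin-4-yl, so no measured compound carries a non-aromatic ring here and the direction remains uncertain. A higher number in this assay is still expected, by a step smaller than the measured one: a 3.7-fold higher number from compound 2 to compound 3 (0.57 log units; beyond the scatter) is the expected change. For compound 3 the estimated value is 500 nM, with an expected range of 120 nM to 2500 nM.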

Compound 3, concentration for 50% growth inhibition: 254 nM
Estimate against measurement, compound 3: 2.0-fold (0.29 log units) above, and the stated range covers the measured number.
By their numbers in this assay, from the lowest: compounds 2 and 3 (each within the scatter of the next); then compound 1.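

In this assay, at this place on a saturated chain carbon bound to an aromatic nitrogen, the change from pyridin-4-yl to cyclohexyl gives a 1.9-fold higher number from compound 2 to compound 3 (0.27 log units; within the scatter), so neither an aromatic ring nor the ring nitrogen with its hydrogen-bond acceptor is needed to hold a number at this level. The same cyclohexyl set against pyridin-2-yl gives a 9.8-fold lower number from compound 1 to compound 3 (0.99 log units; beyond the scatter), which leaves compound 1 apart from both compound 2 and compound 3 and makes pyridin-2-yl, among these three groups, the one that stands out. Nothing at hand explains why pyridin-2-yl differs from the other two rings.

Open, going by these compounds, is how phenyl, which keeps the aromatic ring without the ring nitrogen, or pyridin-3-yl would compare with these three groups. Also open, on these data alone, is whether a piperidine ring, a morpholine ring or a longer chain leading to the ring would hold the number at this place.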